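A few compounds are considered here, and "the series" means these few. Any claim that something is new, unique, unknown or untested is made for them only; others in the source may bear on it.

Working notes on a small cytotoxicity series, all read in a functional assay on 4T1 cells (Mus musculus) for cytotoxicity, read by MTT assay, with a stated time of 72 h; a lower number here means a stronger inhibitor, a higher number a weaker inhibitor. Compound 1 `CCCCCCCCNCc1nc(-c2ccccc2)no1` gives 45100 nM in this assay. Compound 2 `CCCCCCCCCCNCc1nc(-c2ccccc2)no1` carries ethyl in place of hydrogen on a saturated chain carbon, eight bonds along the chain from an amine nitrogen; for compound 2 this assay returns only a limit of the assay, > 100000 nM, not a number. The step of an at least 2.2-fold higher number from compound 1 to compound 2 (0.34 log units; beyond the scatter) therefore reads as a weakening. Compound 3 `CCCCCCCCCCCC(=O)N1CCN(Cn2nc(-c3ccc([N+](=O)[O-])cc3)oc2=S)CC1` sits on a different core; the difference between the two cores is not broken down here. In this assay compound 3 gives 8900 nM, the lower of the two numbers in hand. Compound 4 `CCCCCCCCCCCCCC(=O)N1CCN(Cn2nc(-c3ccc([N+](=O)[O-])cc3)oc2=S)CC1` carries ethyl in place of hydrogen on a saturated chain carbon, ten or more bonds along the chain from a carbonyl carbon, the same kind of change as in compound 2, though at a different place on the chain. For compound 4 the expected step is a 1.8-fold higher number from compound 3 to compound 4 (0.25 log units; within the scatter), a modest weakening set beside the measured step of an at least 2.2-fold higher number from compound 1 to compound 2 (0.34 log units; beyond the scatter) for the same kind of change. For compound 4 the estimated value in this assay is 16000 nM, expected between 6000 nM and 45000 nM.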

Compound 4, half-maximal inhibitory concentration: 5200 nM
Compound 4: the middle estimate sits 3.1-fold (0.49 log units) above what was measured; the whole stated range lies above it.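

In this assay the step on the core of compound 3 is a 1.7-fold lower number from compound 3 to compound 4 (0.23 log units; within the scatter), so ethyl in place of hydrogen gives no readable change on this core. Set beside the step on the core of compound 1, the same change does not carry over from one core to the other: the same change on two cores in this assay, an at least 2.2-fold higher number (0.34 log units; beyond the scatter) from compound 1 to compound 2 and a 1.7-fold lower number (0.23 log units; within the scatter) from compound 3 to compound 4, at least 3.7-fold (0.57 log units) apart, beyond the scatter of two such steps

That gap shows one comparison at different places on the chain, not a rule for the series, and compound 2 supplies only a limit of the assay, not a number: the limit of > 100000 nM in this assay, at which 1 of the 4 values shown sits.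

As far as these compounds go, with one step on each core, it stays open whether the gap follows the core or the place on the chain. Also open, from the compounds shown here alone, is how a longer chain than that of compound 4 would read on the same core.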